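A few compounds are considered here, and "the series" means these few. Any claim that something is new, unique, unknown or untested is made for them only; others in the source may bear on it.

Compound 1 (`COc1ncc(-c2ccc3nc(NC(=O)NCC(=O)N4CCCCC4)nn3c2)cc1NS(=O)(=O)c1ccc(F)cc1`), compound 2 (`COc1ncc(-c2ccc3nc(NC(=O)NCCN4CCCC4)nn3c2)cc1NS(=O)(=O)c1ccc(F)cc1`) and compound 3 (`COc1ncc(-c2ccc3nc(NC(=O)NC4CC4)nn3c2)cc1NS(=O)(=O)c1ccc(F)cc1`) share one core and differ in the group on an amide-type nitrogen. In a functional assay on A549 cells (Homo sapiens) for cytotoxicity, read by MTT assay, with a stated time of 72 h (a higher number here means a weaker inhibitor, a lower number a stronger inhibitor), compound 1 gives 2060 nM and compound 2 gives 960 nM while compound 3 gives 210 nM as the lowest of the three numbers. Compound 4 (`CCCNC(=O)Nc1nc2ccc(-c3cnc(OC)c(NS(=O)(=O)c4ccc(F)cc4)c3)cn2n1`) carries propyl in place of cyclopropyl on an amide-type nitrogen. Among the compounds with values here, two measured steps bear on this change. They are a 9.8-fold lower number from compound 1 to compound 3 (0.99 log units; beyond the scatter) and a 4.6-fold lower number from compound 2 to compound 3 (0.66 log units; beyond the scatter) and both are modest, with cyclopropyl arriving in place of a longer chain. Neither compares a ring with an open chain of the same size, so they offer only a weak hint. A small move towards a higher number in this assay is therefore expected, perhaps barely beyond the scatter. An estimated 1.5-fold higher number from compound 3 to compound 4 (0.18 log units; within the scatter) is what this suggests. For compound 4 the estimated value is 320 nM with an expected range (110 nM to 900 nM).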

Compound 4, half-maximal inhibitory concentration: 220 nM
Beside the measured number, compound 4's estimate is 1.5-fold (0.16 log units) above it; measured number inside the range.
By their numbers in this assay, from the lowest: compounds 3 and 4 (each within the scatter of the next); then compound 2; then compound 1.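

Replacing cyclopropyl with propyl on the amide-type nitrogen gives a 1.0-fold higher number from compound 3 to compound 4 (0.02 log units; within the scatter), so in this assay the closed ring is not required at this position to keep the number where compound 3 has it. The open chain also stands apart from the larger groups, with a 4.4-fold lower number from compound 2 to compound 4 (0.64 log units; beyond the scatter) and a 9.4-fold lower number from compound 1 to compound 4 (0.97 log units; beyond the scatter), so the earlier gaps are not tied to cyclopropyl alone. No measurement is available here to explain why the ring and the chain match.

Going by these compounds, it remains open whether a longer chain such as butyl or a branched group such as isopropyl would keep the number in this range. Also unknown is what a short chain ending in a hydroxyl group or a simple primary amine would do.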